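The compounds below may be only part of what the source reports. "The series", "measured", "known", "first", "only" and "open" are said of these compounds alone.

The three measured compounds share one core. Compound 1 `Cc1nc(-c2cccnc2)sc1-c1nnc(-c2ccncc2)o1` carries a pyridin-4-yl group, compound 2 `Cc1nc(-c2cccnc2)sc1-c1nnc(-c2ccccc2)o1` carries a phenyl, and compound 3 `Cc1nc(-c2cccnc2)sc1-c1nnc(Cc2ccccc2)o1` carries a benzyl. In an ADME assay on THP-1 cells (Homo sapiens) for cytotoxicity, read by MTT assay (on this read-out higher numbers stand for lower toxicity in this test and lower numbers for higher toxicity in this test), compound 1 reaches only the limit of the test, > 100 ug/mL. In this assay compound 2 likewise gives only a limit, > 100 ug/mL. Compound 3 also gives only a limit in this assay, > 100 ug/mL. The steps among them cannot be read: a step that the two limits leave unreadable from compound 1 to compound 2, a step that the two limits leave unreadable from compound 1 to compound 3 and a step that the two limits leave unreadable from compound 2 to compound 3. Going by the values given here, the only evidence is the limit of > 100 ug/mL in this assay, at which 3 of the 3 values shown sit, and compound 2 stands at that limit together with the other two.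

Compound 4 `Cc1nc(-c2cccnc2)sc1-c1nnc(-c2ccccc2[N+](=O)[O-])o1` differs from compound 2 in one place: nitro in place of hydrogen on an aromatic carbon. None of the three measured steps yields a size to carry over; they show only that the aryl and benzyl exchanges made so far left every value at the limit. For compound 4 in this assay a step of a number no higher from compound 2 to compound 4 (the limit leaves the size open) is expected, that is, no departure beyond the scatter from the limit region. Compound 4 is therefore expected to give about 100 ug/mL in this assay, within a range from 40 ug/mL to 200 ug/mL, with a fair chance that again only a limit is reported.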

Compound 4, half-maximal cytotoxic concentration: > 100 ug/mL
Compound 4 ended at the assay's limit (the forecaster's own chance of this, stated with the estimate: 60%); the middle value sits exactly at the limit.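

The step between compound 2 and compound 4 cannot be read, since each gives only a limit, and so the nitro exchange yields no size: the limit of > 100 ug/mL in this assay, at which 4 of the 4 values shown sit.

The compounds shown leave open how far the true value of any of the four lies past that limit in this assay, and whether any of these exchanges changes the read-out at all.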